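A few compounds are considered here, and "the series" means these few. Any claim that something is new, unique, unknown or untested is made for them only; others in the source may bear on it.

Measured compounds:
Compound 1 `O=C(CCCCCc1ccc(I)cc1)N1CCOC1=O`: in an assay on HEK293 cells for inhibition of N-acylethanolamine-hydrolyzing acid amidase (Rattus norvegicus), read by LC-MS, with a stated time of 30 min (a higher number here means a weaker inhibitor, a lower number a stronger inhibitor), compound 1 stops at the assay limit, > 20000 nM.
Compound 2 `O=C1OCCN1C(=O)c1ccc(Oc2ccc(O)cc2)cc1`: in this assay compound 2 also stops at the limit, > 20000 nM.
Compound 3 `O=C1OCCN1C(=O)c1ccc(OC2CCCCC2)cc1`: in this assay compound 3 gives 92 nM.

Among the measured compounds shown here, compound 3 thus carries the only real number in this assay; the two other entries are limits (the limit of > 20000 nM in this assay, at which 2 of the 3 values shown sit). For the measured compounds named here, the single step between measured compounds, an at least 210-fold lower number from compound 2 to compound 3 (2.33 log units; beyond the scatter), came with cyclohexyl in place of 4-hydroxyphenyl on the ether oxygen, a swap of the whole ring, so it does not isolate a hydroxy group on its own.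

Compound 4 `O=C1OCCN1C(=O)c1ccc(OC2CCC(O)CC2)cc1` differs from compound 3 by hydroxy in place of hydrogen on a saturated ring carbon. Going by the values given here, the one measured step bears on this change only loosely: it shows the cyclohexyl ether far stronger than the 4-hydroxyphenyl ether, but offers no direct reading of a hydroxy on a saturated ring. Compound 4 is therefore expected to sit somewhat weaker than compound 3, the estimated step being a 4.3-fold higher number from compound 3 to compound 4 (0.64 log units; beyond the scatter). Compound 4 is estimated at 400 nM, within a range from 90 nM to 3000 nM.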

Compound 4, half-maximal inhibitory concentration: 210 nM
Estimate against measurement, compound 4: 1.9-fold (0.28 log units) above, within the range that was stated.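

Among the compounds shown here, the first direct reading of a hydroxy on the saturated ring comes from this assay, which shows a 2.3-fold higher number from compound 3 to compound 4 (0.36 log units; beyond the scatter), so this ring carbon accepts the hydroxy at a modest cost. With a hydroxy on both sides of the comparison, there is still an at least 95-fold lower number from compound 2 to compound 4 (1.97 log units; beyond the scatter), which ties the large gap to 4-hydroxycyclohexyl in place of 4-hydroxyphenyl, not to the hydroxy as such. The value of compound 2 is a limit, so this step has a bound only: the limit of > 20000 nM in this assay, at which 2 of the 4 values shown sit.

The compounds shown leave open how an amine or a carboxylic acid would fare on this ring carbon, and whether a hydroxy on another carbon of the ring would give a similar number. They also do not tell why the saturated ring and the aromatic ring differ so widely.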